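The source may hold more compounds than are shown below. What is called first, only, known or untested is meant among the compounds shown, and "the series" means these compounds.

Compound 1 `CSCC(=O)N1CCN(c2nc(=O)c3cc(C(F)(F)F)cc([N+](=O)[O-])c3s2)CC1`: > 125000 nM
Compound 2 `CC(=O)N1CCN(c2nc(=O)c3cc(C(F)(F)F)cc([N+](=O)[O-])c3s2)CC1`: > 125000 nM

In an ADME assay on Vero cells (Chlorocebus sabaeus) for cytotoxicity, read by MTT assay, with a stated time of 72 h (a higher number here means that more compound is tolerated, a lower number that less compound is tolerated), compound 1 gives > 125000 nM, which is a limit of the assay and not a number. Compound 2, in this assay, gives > 125000 nM, also a limit. The step that the two limits leave unreadable from compound 1 to compound 2 therefore cannot be read, and what the two measured compounds show amounts to the limit of > 125000 nM in this assay, at which 2 of the 2 values shown sit: neither is toxic enough to register within the tested range.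

Compound 3 `CC(C)(C)C1CCC(C(=O)N2CCN(c3nc(=O)c4cc(C(F)(F)F)cc([N+](=O)[O-])c4s3)CC2)CC1` is not yet measured. It differs from compound 1 by 4-(tert-butyl)cyclohexyl in place of (methylsulfanyl)methyl on a carbonyl carbon. For the measured compounds named here, no measured step touches this carbonyl substituent in a readable way, so the measured compounds give no direction for it; they show only that the shared core tolerates two small acyl groups without toxicity up to the limit.

The step of an at least 1.3-fold lower number from compound 1 to compound 3 (0.14 log units; that floor lies within the scatter) is expected to be small or none beyond the scatter, with a modest chance of lower tolerance. Compound 3 is estimated at 90000 nM, within 20000 nM to 125000 nM.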

Compound 3, half-maximal cytotoxic concentration: > 125000 nM
Compound 3 was reported as a limit; the forecaster's own chance of this, stated with the estimate: 50%; middle value at least 1.3-fold (0.14 log units) away from the limit.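

In this assay, for the compounds shown here, compound 3 gives > 125000 nM, a limit of the assay and not a number, so no step from compound 1 or compound 2 to compound 3 can be read. The compounds shown leave open whether the group on the carbonyl carbon affects tolerance at all.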